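Aryl sulfone variation on a quinoline series

The source may hold more compounds than are shown below. What is called first, only, known or untested is meant among the compounds shown, and "the series" means these compounds.

Measured so far:
compound 1 `COc1ccc(S(=O)(=O)c2cnc3ccc(C)cc3c2N2CCC(C)CC2)cc1Cl` with 93%
compound 2 `Cc1ccc2ncc(S(=O)(=O)c3ccc(C)c(Cl)c3)c(N3CCC(C)CC3)c2c1` with 91%
compound 3 `Cc1ccc2ncc(S(=O)(=O)c3ccc(C)c(F)c3)c(N3CCC(C)CC3)c2c1` with 91%

Compound 3 stands level with compound 2 at the digits printed, the two together the lowest of the three numbers in an assay on isolated protein for displacement of a labelled ligand from metabotropic glutamate receptor 5 (Homo sapiens), with a stated time of 60 min, tested at 1 uM (on this read-out higher numbers stand for more inhibition at the one concentration tested (going by the name of the read-out) and lower numbers for less inhibition), and compound 1 sits a number 2 percentage points lower from compound 1 to compound 3 (within the scatter), which is within the scatter. Compound 4 `Cc1ccc2ncc(S(=O)(=O)c3ccccc3)c(N3CCC(C)CC3)c2c1` is the next member. The change is phenyl in place of 3-fluoro-4-methylphenyl on a sulfonyl sulfur. Going by the values given here, the steps that bear on it are a number 2 percentage points lower from compound 1 to compound 2 (within the scatter), a number 2 percentage points lower from compound 1 to compound 3 (within the scatter) and no change at the digits printed from compound 2 to compound 3 (within the scatter), all within the scatter. None of them removes both groups from that ring, so some drop is plausible, but the evidence so far gives no step beyond the scatter. For compound 4 the estimate is 84%, range 62% to 97%, meaning an expected step of a number 7 percentage points lower from compound 3 to compound 4 (within the scatter).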

Compound 4, a percentage reported as inhibition, at one concentration (the size of the read-out at that concentration, not a potency): 67%
Compound 4: middle estimate off by 17 percentage points, on the high side, within the range that was stated.
By their numbers in this assay, from the lowest: compound 4; then compounds 2, 3 and 1 (each within the scatter of the next).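

In this assay, going by these compounds alone, bare phenyl is the first change on the sulfonyl sulfur to register beyond the scatter: a number 24 percentage points lower from compound 3 to compound 4 (beyond the scatter), a number 24 percentage points lower from compound 2 to compound 4 (beyond the scatter) and a number 26 percentage points lower from compound 1 to compound 4 (beyond the scatter). Compound 4 thus stands apart from the three substituted compounds, so keeping at least one substituent on this ring matters, although the steps among those three do not separate their substituents. No measurement shown accounts for the loss. Still open, as far as these compounds go, is whether a lone methyl or a lone fluoro on the phenyl restores the number, and how a nitrile or a carboxylic acid on that ring would read.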